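The source may report more compounds than this note shows. Statements on the series, on what has been measured and on what is new or still open speak of the compounds shown alone.

Of the compounds shown here, three built on one shared core have been measured in a functional assay on MCF7 cells (Homo sapiens) for antiproliferative activity, read by CCK-8 assay, with a stated time of 72 h; a higher number here means a weaker inhibitor, a lower number a stronger inhibitor. Compound 1 `COc1ccccc1C(=O)Nc1cccc(-c2oc3cc(-c4ccc(F)cc4)ccc3c(=O)c2O)c1` gives 2100 nM. Compound 2 `Cc1cccc(C(=O)Nc2cccc(-c3oc4cc(-c5ccc(F)cc5)ccc4c(=O)c3O)c2)c1` gives 7850 nM. Compound 3 `O=C(Nc1cccc(-c2oc3cc(-c4ccc(F)cc4)ccc3c(=O)c2O)c1)c1cccc(F)c1` gives 5770 nM. Compound 3 thus stands second highest of the three numbers: its value lies within the scatter of compound 2, as the step of a 1.4-fold lower number from compound 2 to compound 3 (0.13 log units; within the scatter) shows, and beyond the scatter of compound 1, as the step of a 2.7-fold higher number from compound 1 to compound 3 (0.44 log units; beyond the scatter) shows. The unmeasured compound 4 `Cc1cc(C)cc(C(=O)Nc2cccc(-c3oc4cc(-c5ccc(F)cc5)ccc4c(=O)c3O)c2)c1` differs from compound 3 in one place: 3,5-dimethylphenyl in place of 3-fluorophenyl on a carbonyl carbon. Among the measured compounds shown here, two measured steps bear on this. The steps of a 3.7-fold higher number from compound 1 to compound 2 (0.57 log units; beyond the scatter) and a 2.7-fold higher number from compound 1 to compound 3 (0.44 log units; beyond the scatter) show that a 3-methylphenyl and a 3-fluorophenyl on the carbonyl carbon each give a higher number than the 2-methoxyphenyl, while the step of a 1.4-fold lower number from compound 2 to compound 3 (0.13 log units; within the scatter) shows methyl and fluoro on that ring giving values within the scatter of one another. For the measured compounds named here, no measured compound tells how a second methyl on that ring acts. Compound 4 is therefore expected to move by a 1.4-fold higher number from compound 3 to compound 4 (0.14 log units; within the scatter), a step that may well fall within the scatter. The estimate for compound 4 in this assay is 8000 nM, between 3500 nM and 18000 nM.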

Compound 4, half-maximal inhibitory concentration: 20400 nM
Compound 4: the middle estimate sits 2.6-fold (0.41 log units) below what was measured, outside the stated range (above it).
By their numbers in this assay, from the lowest: compound 1; then compounds 3 and 2 (each within the scatter of the next); then compound 4.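

In this assay, a second methyl on the ring at the carbonyl carbon does register, as methyl in place of hydrogen gives a 2.6-fold higher number from compound 2 to compound 4 (0.41 log units; beyond the scatter), whereas methyl and fluoro on that ring had stayed within the scatter of one another. The 3,5-dimethylphenyl also stands clear of the 3-fluorophenyl, with a 3.5-fold higher number from compound 3 to compound 4 (0.55 log units; beyond the scatter), and of the 2-methoxyphenyl, with a 9.7-fold higher number from compound 1 to compound 4 (0.99 log units; beyond the scatter), the widest of the steps shown here. Nothing available explains why the number rises with this change.

The compounds shown leave open whether a 3,5-difluorophenyl would raise the number as the 3,5-dimethylphenyl does, which would separate the effect of a second group from that of methyl itself. They also leave open how an amine or a carboxylic acid on that ring would compare with the 2-methoxyphenyl.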